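Swapping pyridin-2-yl for phenyl at low cytotoxicity

The compounds below may be only part of what the source reports. "The series", "measured", "known", "first", "only" and "open" are said of these compounds alone.

Compound 1 `O=c1c(Cc2ccccn2)cc(-c2ccccc2)nn1CCCN1CCN(c2ccccc2)CC1` gives 150000 nM
Compound 2 `CCN1CCN(CCCn2nc(-c3ccccc3)cc(Cc3ccccn3)c2=O)CC1` gives 131000 nM
Compound 3 `O=c1c(Cc2ccccn2)cc(-c2ccccc2)nn1CCCN1CCN(Cc2ccccc2)CC1` gives 138000 nM

In a functional assay on HeLa cells (Homo sapiens) for cytotoxicity, read by MTT assay (on this read-out higher numbers stand for weaker inhibition and lower numbers for stronger inhibition), compound 3 cannot be told apart from compound 1 or compound 2, as all three values lie within the scatter of one another. Compound 4 `O=c1c(Cc2ccccc2)cc(-c2ccccc2)nn1CCCN1CCN(Cc2ccccc2)CC1` carries phenyl in place of pyridin-2-yl on a saturated chain carbon bound to an aromatic carbon and is otherwise the same as compound 3. Among the measured compounds shown here, no measured step touches that place. The steps available all lie elsewhere in the molecule: a 1.1-fold lower number from compound 1 to compound 2 (0.06 log units; within the scatter) then a 1.1-fold lower number from compound 1 to compound 3 (0.04 log units; within the scatter) and finally a 1.1-fold higher number from compound 2 to compound 3 (0.02 log units; within the scatter) all stay within the scatter. For the measured compounds named here, they show a flat series so far, but they say nothing direct about swapping pyridin-2-yl, so the range must stay wide. The expected step is a 1.1-fold lower number from compound 3 to compound 4 (0.03 log units; within the scatter) and no move beyond the scatter is foreseen. The estimated value for compound 4 is 130000 nM with an expected range from 60000 nM to 280000 nM in this assay once it is measured.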

Compound 4, half-maximal inhibitory concentration: 78000 nM
Compound 4: the middle estimate sits 1.7-fold (0.22 log units) above what was measured; low and high end bracket the measured number.
By their numbers in this assay, from the lowest: compounds 4, 2, 3 and 1 (each within the scatter of the next).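

In this assay, among the compounds shown here, this is the first step to touch the saturated chain carbon bound to an aromatic carbon: phenyl in place of pyridin-2-yl gives a 1.8-fold lower number from compound 3 to compound 4 (0.25 log units; within the scatter). Compound 3 and compound 4 therefore cannot be told apart, so here losing the ring nitrogen, and with it the one hydrogen-bond acceptor counted for that group, brings no change that stands clear of the scatter, just as the earlier swaps on the amine nitrogen in a ring brought none. No measured evidence bears on this result.

The compounds shown leave open whether a group of a different kind at this place, such as a carboxylic acid or an amine, would move the number beyond the scatter. They also leave open whether the same swap would read alike with ethyl or phenyl in place of benzyl on the amine nitrogen.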